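Urea aryl group variation in one cytotoxicity series

This account rests on a few compounds, and the source may have more. Where it says the series, first, only, none or still open, it means among the compounds named here.

Measured compounds:
- Compound 1 `CCN(CC)CCNc1nc(-c2ccc(NC(=O)Nc3ccc(F)cc3)cc2)nc2c(Cl)c(Cl)sc12`: in a functional assay on MDA-MB-231 cells (Homo sapiens) for cytotoxicity, read by MTT assay, with a stated time of 72 h (on this read-out higher numbers stand for weaker inhibition and lower numbers for stronger inhibition), compound 1 gives 1130 nM.
- Compound 2 `CCN(CC)CCNc1nc(-c2ccc(NC(=O)Nc3ccc(Cl)cc3Cl)cc2)nc2c(Cl)c(Cl)sc12`: in this assay compound 2 gives 1920 nM.
- Compound 3 `CCN(CC)CCNc1nc(-c2ccc(NC(=O)Nc3ccc(C)cc3)cc2)nc2c(Cl)c(Cl)sc12`: not yet measured.

Within the data shown here, compound 2 holds the highest of the two numbers so far, but its only neighbour is compound 1, and the step of a 1.7-fold higher number from compound 1 to compound 2 (0.23 log units; within the scatter) lies within the scatter, so the two compounds cannot be ordered against each other on this read-out.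

The move to compound 3 is 4-methylphenyl in place of 2,4-dichlorophenyl on an amide-type nitrogen. Among the measured compounds shown here, the only measured step that bears on this position is the exchange of the urea aryl group from compound 1 to compound 2, a 1.7-fold higher number from compound 1 to compound 2 (0.23 log units; within the scatter), which did not reach beyond the scatter. Two different aryl groups at this position therefore gave numbers that cannot be told apart, and the data give no reason to expect a third aryl group to behave otherwise. The expectation for compound 3 in this assay is accordingly no step beyond the scatter, a 1.4-fold lower number from compound 2 to compound 3 (0.14 log units; within the scatter), with the estimate placed between the two known values rather than at either end.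

Compound 3 is thus estimated at 1400 nM, with a plausible range from 600 nM to 3500 nM.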

Compound 3, half-maximal inhibitory concentration: 2010 nM
For compound 3 the middle estimate is 1.4-fold (0.16 log units) below the measured one, and the stated range covers the measured number.
By their numbers in this assay, from the lowest: compounds 1, 2 and 3 (each within the scatter of the next).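

In this assay the urea aryl position now carries three different groups, and 4-methylphenyl in place of 2,4-dichlorophenyl gives a 1.0-fold higher number from compound 2 to compound 3 (0.02 log units; within the scatter) while methyl in place of fluoro on an aromatic carbon gives a 1.8-fold higher number from compound 1 to compound 3 (0.25 log units; within the scatter) so neither exchange leaves the scatter. The new information is that a phenyl group carrying only carbon cannot be told apart from either halogen-bearing aryl group on this read-out, so among these three compounds the presence of fluoro or chlorine on this ring does not separate the numbers, and no compound in the set goes against this. No measured evidence is available that would explain this flat result.

On these data alone, whether any group at this position can move the number beyond the scatter stays open, since all three compounds carry a substituted phenyl and a carboxylic acid or a morpholine on that ring, or a pyridine in its place, has no reading here. As far as these compounds go, the amine side chain on the shared core is also the same throughout, so the outcome of a longer chain or a piperazine at that place remains unknown.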